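Imidazolyl in place of phenyl: estimate for compound 4

This account rests on a few compounds, and the source may have more. Where it says the series, first, only, none or still open, it means among the compounds named here.

Going by the values given here, compound 1 `CCC(C)n1ncn(-c2ccc(N3CCN(c4ccc(OC[C@@H]5CO[C@@](Cc6ccccc6)(c6ccc(Cl)cc6Cl)O5)cc4)CC3)cc2)c1=O` gives 513 nM in a functional assay on HUVEC cells (Homo sapiens), read by scintillation counting and thymidine incorporation, with a stated time of 24 h (a lower number here means a stronger inhibitor, a higher number a weaker inhibitor), the highest of the three numbers measured so far. Compound 2 `CCC(C)n1ncn(-c2ccc(N3CCN(c4ccc(OC[C@@H]5CO[C@@](Cn6ccnc6-c6ccccc6)(c6ccc(Cl)cc6Cl)O5)cc4)CC3)cc2)c1=O` gives 136 nM and compound 3 `CCC(C)n1ncn(-c2ccc(N3CCN(c4ccc(OC[C@@H]5CO[C@@](Cn6cnc(C)c6)(c6ccc(Cl)cc6Cl)O5)cc4)CC3)cc2)c1=O` gives 102 nM. Compound 4 `CCC(C)n1ncn(-c2ccc(N3CCN(c4ccc(OC[C@@H]5CO[C@@](Cn6c(C)cnc6C)(c6ccc(Cl)cc6Cl)O5)cc4)CC3)cc2)c1=O` differs from compound 1 by 2,5-dimethyl-1H-imidazol-1-yl in place of phenyl on a saturated chain carbon bound to a saturated ring carbon. Among the compounds with values here, two measured steps bear on this change: a 3.8-fold lower number from compound 1 to compound 2 (0.58 log units; beyond the scatter) and a 5.0-fold lower number from compound 1 to compound 3 (0.70 log units; beyond the scatter), both beyond the scatter and in the same direction, while the step of a 1.3-fold lower number from compound 2 to compound 3 (0.12 log units; within the scatter) lies within the scatter. A third imidazolyl variant is therefore expected to give a step of similar size and direction, with no basis for ranking it against the other two. The estimate for compound 4 is 120 nM, expected as a 4.3-fold lower number from compound 1 to compound 4 (0.63 log units; beyond the scatter), within an expected range from 55 nM to 260 nM.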

Compound 4, half-maximal inhibitory concentration: 765 nM
The estimate for compound 4 lay 6.4-fold (0.80 log units) below the measured number, outside the stated range (above it).
By their numbers in this assay, from the lowest: compounds 3 and 2 (each within the scatter of the next); then compounds 1 and 4 (each within the scatter of the next).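

Imidazolyl in place of phenyl on a saturated chain carbon bound to a saturated ring carbon does not by itself lower the number in this assay: with 2,5-dimethyl-1H-imidazol-1-yl, the result is a 1.5-fold higher number from compound 1 to compound 4 (0.17 log units; within the scatter). The substituents on the imidazole therefore matter, with the two other imidazolyl variants separated from this one by a 7.5-fold higher number from compound 3 to compound 4 (0.88 log units; beyond the scatter) and a 5.6-fold higher number from compound 2 to compound 4 (0.75 log units; beyond the scatter). No measurement available here accounts for these gaps.

Which of the two methyl groups carries the difference remains open. So does the reading of an unsubstituted imidazolyl or a triazolyl group at this place.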